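Restoring a Phenol on the Benzamide

The source may hold more compounds than are shown below. What is called first, only, known or untested is meant among the compounds shown, and "the series" means these compounds.

Compound 1, `O=C(Nc1ccc(Sc2nc3ccccc3s2)c(Cl)c1)c1cc(Br)cc(Br)c1O`: 4200 nM
Compound 2, `COc1c(Br)cccc1C(=O)Nc1ccc(Sc2nc3ccccc3s2)c(Cl)c1`: > 100000 nM

In an assay for inhibition of HSP60/HSP10 (Homo sapiens), with a stated time of 60 min (on this read-out lower numbers stand for stronger inhibition and higher numbers for weaker inhibition), compound 1 gives 4200 nM. Compound 2 reaches only a limit of the assay, > 100000 nM, so compound 2 stands at the limit of > 100000 nM in this assay, at which 1 of the 2 values shown sits, the weaker end of the pair. Compound 3, `O=C(Nc1ccc(Sc2nc3ccccc3s2)c(Cl)c1)c1cc(Br)ccc1O`, differs from compound 2 by a group of 8 heavy atoms (6 carbon, 1 oxygen, 1 bromine; one six-membered aromatic ring of carbon only) in place of a group of 9 heavy atoms (7 carbon, 1 oxygen, 1 bromine; one six-membered aromatic ring of carbon only), on a carbonyl carbon. Among the compounds with values here, the only measured step, an at least 23-fold higher number from compound 1 to compound 2 (1.37 log units; beyond the scatter), concerns the same carbonyl position and was large. A large step back towards stronger inhibition in this assay is therefore expected, an at least 10-fold lower number from compound 2 to compound 3 (1.00 log units; beyond the scatter). Compound 3 is estimated at 10000 nM, within 3000 nM to 50000 nM.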

Compound 3, half-maximal inhibitory concentration: > 100000 nM
Compound 3 gave a limit, no number (the forecaster's own chance of this, stated with the estimate: 20%); at least 10-fold (1.00 log units) between middle value and limit.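

The hydroxyl of the 5-bromo-2-hydroxyphenyl group does not by itself restore a readable value in this assay, since compound 3 remains at a limit of the assay. What compound 3 adds is that the second bromo of compound 1 matters at this position, as hydrogen in place of that bromo gives an at least 23-fold higher number from compound 1 to compound 3 (1.37 log units; beyond the scatter). The step between compound 2 and compound 3 cannot be read, because both stop at the same limit: the limit of > 100000 nM in this assay, at which 2 of the 3 values shown sit.

Still open, from the compounds shown here alone, is whether chlorine in place of the remaining bromo would bring back a readable value. So is the effect of an amine in place of the hydroxyl.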